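Carboxymethylamino in place of methoxy on a quinone-like core

This account rests on a few compounds, and the source may have more. Where it says the series, first, only, none or still open, it means among the compounds named here.

Measured compounds:
compound 1 `C=C1CCC[C@H]2[C@](C)(CC3=C(O)C(=O)C=C(OC)C3=O)[C@@H](C)CC[C@]12C` gives 1800 nM
compound 2 `C=C1CCC[C@H]2[C@](C)(Cc3c(O)c(O)cc4ncoc34)[C@@H](C)CC[C@]12C` gives 24000 nM

Both compounds share the same terpene-like core and were tested in a functional assay on NCI-H460 cells (Homo sapiens) for cytotoxicity, read by sulforhodamine B assay, with a stated time of 48 h; on this read-out lower numbers stand for stronger inhibition of growth and higher numbers for weaker inhibition of growth. Compound 1 `C=C1CCC[C@H]2[C@](C)(CC3=C(O)C(=O)C=C(OC)C3=O)[C@@H](C)CC[C@]12C` has the lowest number of the two, giving 1800 nM in this assay; compound 2 `C=C1CCC[C@H]2[C@](C)(Cc3c(O)c(O)cc4ncoc34)[C@@H](C)CC[C@]12C` gives 24000 nM in this assay, a gap that lies beyond the scatter of repeated measurements. Going by the values given here, since the two differ in more than one place, their values show only that compound 1 is the stronger inhibitor of growth here.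

The step from compound 1 to compound 3 `C=C1CCC[C@H]2[C@](C)(CC3=C(O)C(=O)C=C(NCC(=O)O)C3=O)[C@@H](C)CC[C@]12C` changes one spot on the ring of compound 1: (carboxymethyl)amino in place of methoxy on a double-bonded ring carbon. No comparable single change is available among the measured compounds, so the size of this step cannot be read from data. The expectation is a modest step toward a higher number, possibly within the scatter.

Compound 3 is therefore expected to give about 4000 nM in this assay, with a range from 1500 nM to 12000 nM, which means an estimated step of a 2.2-fold higher number from compound 1 to compound 3 (0.35 log units; beyond the scatter).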

Compound 3, concentration for 50% growth inhibition: 6000 nM
Compound 3: middle estimate off by 1.5-fold (0.18 log units), on the low side; measured number inside the range.
By their numbers in this assay, from the lowest: compound 1; then compound 3; then compound 2.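

In this assay, going by these compounds alone, putting (carboxymethyl)amino in place of methoxy on the double-bonded ring carbon gives a 3.3-fold higher number from compound 1 to compound 3 (0.52 log units; beyond the scatter), which is the first single-place change that can be read at this position. It shows that the group on this ring carbon matters, although the step is modest: compound 3, whose new group brings more heavy atoms and hydrogen-bond donors than methoxy, still gives a measurable growth-inhibition value of 6000 nM in this assay. The data at hand offer no measurement that explains this step.

The new group differs from methoxy in several ways at once, as it has a nitrogen attached to the ring, a short chain and a carboxylic acid at its end, so the compounds shown leave open which of these parts accounts for the step. A plain amino group, a methylamino group, the methyl ester of this acid or a longer chain ending in a carboxylic acid at the same ring carbon would help separate these parts, while compound 2 differs from the others in more than one place and cannot be read as a step.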